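Phenyl for thiophen-3-yl: notes on the step to compound 4

The source may hold more compounds than are shown below. What is called first, only, known or untested is meant among the compounds shown, and "the series" means these compounds.

Measured in an ADME assay on MRC5 cells (Homo sapiens), read by MTT assay, with a stated time of 72 h; on this read-out higher numbers stand for weaker inhibition and lower numbers for stronger inhibition:
Compound 1 `CSc1ncnc2c1c(-c1ccoc1)cn2[C@@H]1O[C@H](CO)[C@@H](O)[C@H]1O` limit > 100000 nM
Compound 2 `CSc1ncnc2c1c(-c1cccs1)cn2[C@@H]1O[C@H](CO)[C@@H](O)[C@H]1O` limit > 100000 nM
Compound 3 `CSc1ncnc2c1c(-c1ccsc1)cn2[C@@H]1O[C@H](CO)[C@@H](O)[C@H]1O` limit > 100000 nM

Compound 3 stands at > 100000 nM which is a limit and not a number. Among the compounds with values here, the whole series so far rests on the limit of > 100000 nM in this assay, at which 3 of the 3 values shown sit, with no number to rank the compounds.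

The next compound is compound 4 `CSc1ncnc2c1c(-c1ccccc1)cn2[C@@H]1O[C@H](CO)[C@@H](O)[C@H]1O` which carries phenyl in place of thiophen-3-yl on an aromatic carbon on the shared core.

Within the data shown here, three measured steps bear on this change, each an exchange of one aromatic ring for another at the same place. They are a step that the two limits leave unreadable from compound 1 to compound 2 together with a step that the two limits leave unreadable from compound 1 to compound 3 and a step that the two limits leave unreadable from compound 2 to compound 3 and none of them gives a size. Among the measured compounds shown here, no measured step yet moves from a five-membered ring to a six-membered ring of carbon only, so the guide is weak.

With compound 3 at the limit of > 100000 nM as the only anchor, no step beyond the usual scatter is expected in this assay and no direction can be named. The expected move is a number no higher from compound 3 to compound 4 (the limit leaves the size open) as estimated here. The estimated value for compound 4 is 100000 nM within an expected range of 40000 nM to 200000 nM and a report as a limit again is likely.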

Compound 4, half-maximal inhibitory concentration: > 100000 nM
Compound 4 gave a limit, no number; the forecaster's own chance of this, stated with the estimate: 70%; the middle value sits exactly at the limit.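

In this assay compound 4 again gives a limit and not a number, so none of the steps linking compound 1, compound 2, compound 3 and compound 4 can be read, and the series still rests on one value: the limit of > 100000 nM in this assay, at which 4 of the 4 values shown sit.

The compounds shown leave open whether furan-3-yl, thiophen-2-yl, thiophen-3-yl and phenyl differ at all on this read-out.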